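Replacing a pyridine with naphthalene on the chain end

The source may report more compounds than this note shows. Statements on the series, on what has been measured and on what is new or still open speak of the compounds shown alone.

Measured compounds:
- Compound 1, `O=c1[nH]/c(=N\OCCCCc2ccccc2)ccn1[C@@H]1O[C@H](COP(=O)(O)OP(=O)(O)OP(=O)(O)O)[C@@H](O)[C@H]1O`: 54 nM
- Compound 2, `O=c1[nH]/c(=N\OCCCc2ccc(I)cc2)ccn1[C@@H]1O[C@H](COP(=O)(O)OP(=O)(O)OP(=O)(O)O)[C@@H](O)[C@H]1O`: 91 nM
- Compound 3, `O=c1[nH]/c(=N\OCCCc2ccncc2)ccn1[C@@H]1O[C@H](COP(=O)(O)OP(=O)(O)OP(=O)(O)O)[C@@H](O)[C@H]1O`: 250 nM

All three share one core and differ only in the ring at the far end of the chain. In a functional assay on 1321-N1 cells for agonist activity at P2Y purinoceptor 4 (Homo sapiens), read by scintillation counting and inositol phosphate accumulation (a lower number here means that less compound is needed, a higher number that more compound is needed for the effect), compound 3 gives the highest number of the three; the step of a 2.7-fold higher number from compound 2 to compound 3 (0.44 log units; beyond the scatter) and the step of a 4.6-fold higher number from compound 1 to compound 3 (0.67 log units; beyond the scatter) both lie beyond the scatter, so compound 3 needs the most compound for its effect. Compound 4, `O=c1[nH]/c(=N\OCCCc2ccc3ccccc3c2)ccn1[C@@H]1O[C@H](COP(=O)(O)OP(=O)(O)OP(=O)(O)O)[C@@H](O)[C@H]1O`, has not been measured yet. The change from compound 3 is naphthalen-2-yl in place of pyridin-4-yl on a saturated chain carbon, three bonds along the chain from an oxygen. The two steps that bear on it both show that carbon-only rings at this place give lower numbers than pyridin-4-yl; compound 1 and compound 2 differ from each other only within the scatter. Since naphthalen-2-yl is again a ring of carbon only, compound 4 is expected to return toward those values, with a step of a 3.1-fold lower number from compound 3 to compound 4 (0.49 log units; beyond the scatter) in this assay. The estimate for compound 4 is 80 nM, in the range 25 nM to 250 nM.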

Compound 4, half-maximal effective concentration: 128 nM
Compound 4: middle estimate off by 1.6-fold (0.20 log units), on the low side; the range from low to high includes it.
By their numbers in this assay, from the lowest: compounds 1, 2, 4 and 3 (each within the scatter of the next, the first and the last beyond it).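

In this assay, naphthalen-2-yl in place of pyridin-4-yl gives a 2.0-fold lower number from compound 3 to compound 4 (0.29 log units; within the scatter) and so cannot be told apart from repeat-measurement noise. Naphthalen-2-yl in place of 4-iodophenyl gives a 1.4-fold higher number from compound 2 to compound 4 (0.15 log units; within the scatter) and is also unresolved, while naphthalen-2-yl in place of benzyl gives a 2.4-fold higher number from compound 1 to compound 4 (0.37 log units; beyond the scatter) as a real but modest gap. The clear separation of carbon-only rings from pyridin-4-yl seen earlier therefore does not extend cleanly to this new ring, with compound 4 the exception, since it sits level with both compound 3 and compound 2.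

On these data alone, it remains open how an amine or a carboxylic acid on the end ring, or a longer chain carrying naphthalen-2-yl, would read in this assay. No measurement at hand explains these differences.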